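The compounds below may be only part of what the source reports. "The series", "measured", "known", "first", "only" and "open" are said of these compounds alone.

Working notes on the series. The shared core carries a sugar in compound 2 `O=c1[nH]c(=O)n([C@H]2C[C@H](O)[C@@H](CO)O2)cc1/C=N/O` and compound 3 `O=c1[nH]c(=O)n([C@H]2C[C@H](O)[C@@H](CO)O2)cc1C#CCCCO`, while compound 1 `O=C(/C=C/c1cc(=O)[nH]c(=O)n1COCCO)c1ccccc1` has an open-chain substituent on the ring nitrogen. In an ADME assay on L1210/0 cells (Mus musculus) for cytotoxicity, with a stated time of 48 h (on this read-out lower numbers stand for stronger inhibition and higher numbers for weaker inhibition), compound 1 gives 43300 nM. In the same assay compound 2 gives 15500 nM. For compound 3 the assay reports only a limit, > 200000 nM, so its number is not known. This puts compound 3 at the weak end of the three, at the limit of > 200000 nM in this assay, at which 1 of the 3 values shown sits. Within the data shown here, the one step measured within one change, an at least 12-fold higher number from compound 2 to compound 3 (1.11 log units; beyond the scatter), is large and points to weaker inhibition on going to the longer chain.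

Among the measured compounds shown here, compound 4 `C=CC#Cc1cn([C@H]2C[C@H](O)[C@@H](CO)O2)c(=O)[nH]c1=O` is the next member. vinyl in place of 3-hydroxypropyl on a triple-bonded carbon The change sits on the same chain that entered in the step from compound 2 to compound 3, but shortens it and removes the hydroxyl; none of the measured steps covers this shift directly. With compound 3 already at the limit, the expected outcome for compound 4 is an unchanged or only modestly changed read-out in this assay, that is a step of an at least 1.3-fold lower number from compound 3 to compound 4 (0.12 log units; that floor lies within the scatter) that may not be resolved beyond the scatter. Compound 4 is therefore estimated at 150000 nM, within 40000 nM to 400000 nM, with a fair chance that only a limit is reported again.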

Compound 4, half-maximal inhibitory concentration: > 200000 nM
Compound 4 gave a limit, no number; the forecaster's own chance of this, stated with the estimate: 45%; middle value at least 1.3-fold (0.12 log units) from the limit.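

On the triple-bonded carbon, vinyl in place of 3-hydroxypropyl leaves the read-out in this assay at the limit of the assay, so the weak result does not depend on the hydroxyl of the chain in compound 3: the limit of > 200000 nM in this assay, at which 2 of the 4 values shown sit. The step between compound 3 and compound 4 cannot be read, as both carry only a limit, and no difference between the two chains can be stated. Relative to the group in compound 2, the all-carbon group on the aromatic carbon gives an at least 12-fold higher number from compound 2 to compound 4 (1.11 log units; beyond the scatter), so a large step now appears with a second chain that has no oxygen, while compound 2 remains the only one of these three sugar-bearing compounds with a measured number.

As far as these compounds go, how far compound 3 and compound 4 lie past the limit remains unknown, and a difference between them could be hidden there. Also open, from the compounds shown here alone, is whether an amine or a carboxylic acid on the chain, or a nitrile directly on the aromatic carbon, would bring the read-out back towards that of compound 2.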